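Re-adding a Sulfonyl, Now Methylated, to Compound 2

The source may hold more compounds than are shown below. What is called first, only, known or untested is meant among the compounds shown, and "the series" means these compounds.

Measured compounds:
Compound 1 `CCS(=O)(=O)Nc1cccc2c1CCCC2c1c[nH]cn1`: 1070 nM
Compound 2 `Nc1cccc2c1CCCC2c1c[nH]cn1`: 191 nM

In an assay on isolated protein for binding affinity to Alpha-1D adrenergic receptor (Rattus norvegicus), read by radioligand binding (on this read-out higher numbers stand for weaker inhibition and lower numbers for stronger inhibition), compound 2 stands at the lowest of the two numbers, the nearest being compound 1 at 1070 nM. Compound 3 `CN(c1cccc2c1CCCC2c1c[nH]cn1)S(C)(=O)=O` differs from compound 2 by methyl(methylsulfonyl)amino in place of amino on an aromatic carbon. Among the measured compounds shown here, the one measured step that bears on this change is a 5.6-fold lower number from compound 1 to compound 2 (0.75 log units; beyond the scatter), where taking the ethylsulfonyl off the nitrogen lowered the number. Compound 3 moves in the opposite direction: a methylsulfonyl returns to the nitrogen, and the group now brings no hydrogen-bond donor. For the measured compounds named here, no measured pair shows what the added methyl does on its own, so the expectation rests on the reversed step alone. The step expected here is a 7.9-fold higher number from compound 2 to compound 3 (0.90 log units; beyond the scatter), upward and roughly the mirror of the measured one, with wide uncertainty. Compound 3 is estimated at 1500 nM, in a range from 400 nM to 6000 nM.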

Compound 3, inhibition constant: 708 nM
Beside the measured number, compound 3's estimate is 2.1-fold (0.33 log units) above it; low and high end bracket the measured number.
By their numbers in this assay, from the lowest: compound 2; then compounds 3 and 1 (each within the scatter of the next).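

In this assay, both sulfonyl-bearing groups on this aromatic carbon read worse than the plain amino group, and methyl(methylsulfonyl)amino gives a 3.7-fold higher number from compound 2 to compound 3 (0.57 log units; beyond the scatter). Exchanging (ethylsulfonyl)amino for methyl(methylsulfonyl)amino produces no readable difference, with a 1.5-fold lower number from compound 1 to compound 3 (0.18 log units; within the scatter), so compound 2 alone stands apart from the other two and the two sulfonyl-bearing groups cannot be told apart here. Nothing available explains why the amino group gives the lower number.

As far as these compounds go, compound 3 differs from compound 1 both in the chain on sulfur and in the methyl on nitrogen, so the contribution of each change, and whether they offset each other, remains open. Also open, from the compounds shown here alone, is how a methylamino group or an acetyl amide, neither carrying a sulfonyl, would read at this position.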